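Swapping fluoro for bromo on compound 3

The source may report more compounds than this note shows. Statements on the series, on what has been measured and on what is new or still open speak of the compounds shown alone.

In a functional assay on A-375 cells (Homo sapiens) for antiproliferative activity, read by MTT assay, with a stated time of 72 h (on this read-out higher numbers stand for weaker inhibition and lower numbers for stronger inhibition), compound 1 `NC(=S)N1N=C(c2ccc(N3CCCCC3)cc2)CC1c1ccc(Cl)cc1` gives > 100000 nM as a limit of the assay, not a number. In this assay compound 2 `Clc1ccc(C2CC(c3ccc(N4CCCCC4)cc3)=NN2c2nc(-c3ccccc3)cs2)cc1` gives 65800 nM and compound 3 `Fc1ccc(-c2csc(N3N=C(c4ccc(N5CCCCC5)cc4)CC3c3ccc(Cl)cc3)n2)cc1` gives 71400 nM as its value, so compound 3 stands level with compound 2. Compound 4 `Clc1ccc(C2CC(c3ccc(N4CCCCC4)cc3)=NN2c2nc(-c3ccc(Br)cc3)cs2)cc1` differs from compound 3 by bromo in place of fluoro on an aromatic carbon at the same spot. The closest guide is fluoro in place of hydrogen there (a 1.1-fold higher number from compound 2 to compound 3 (0.04 log units; within the scatter)), which stayed within the scatter. The changes on the amine nitrogen (an at least 1.5-fold lower number from compound 1 to compound 2 (0.18 log units; that floor lies within the scatter) and an at least 1.4-fold lower number from compound 1 to compound 3 (0.14 log units; that floor lies within the scatter)) start from a limit and concern another place. The expected step (a 1.2-fold lower number from compound 3 to compound 4 (0.08 log units; within the scatter)) therefore stays within the scatter. For compound 4 the estimate is 60000 nM, with an expected range from 25000 nM to 100000 nM.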

Compound 4, half-maximal inhibitory concentration: > 100000 nM
Compound 4 was reported as a limit (the forecaster's own chance of this, stated with the estimate: 20%); middle value at least 1.6-fold (0.22 log units) away from the limit.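

Compound 4 is a limit in this assay and not a number, the first at this position, so this change has a floor but no readable size: the limit of > 100000 nM in this assay, at which 2 of the 4 values shown sit.
The change reads as an at least 1.4-fold higher number from compound 3 to compound 4 (0.14 log units; that floor lies within the scatter) and as an at least 1.5-fold higher number from compound 2 to compound 4 (0.18 log units; that floor lies within the scatter) and both floors lie within the scatter, so bromo may or may not differ from fluoro or hydrogen here.
The step from compound 1 to compound 4 cannot be read: both ends are limits.

Going by these compounds, how far compound 4 truly sits from compound 3 stays open. So does the effect of an amine or a carboxylic acid at this same place.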